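Amide-End Variation in the Shared-Core Series, Cytotoxicity Notes

A few compounds are considered here, and "the series" means these few. Any claim that something is new, unique, unknown or untested is made for them only; others in the source may bear on it.

The two measured compounds share one core and differ only at the amide end. Compound 1 `O=C(NCc1ccncc1)C1CCN(C(=O)c2cc3ccccc3n2Cc2ccc(Cl)cc2)CC1` is the pyridin-4-yl member. In an ADME assay on BE(2)-C cells (Homo sapiens) for cytotoxicity, read by MTT assay, with a stated time of 20 h (on this read-out higher numbers stand for lower toxicity in this test and lower numbers for higher toxicity in this test), compound 1 reaches only the limit of > 100000 nM, not a number. Compound 2 `Cn1ccc(CNC(=O)C2CCN(C(=O)c3cc4ccccc4n3Cc3ccc(Cl)cc3)CC2)n1` carries 1-methyl-1H-pyrazol-3-yl in place of pyridin-4-yl on a saturated chain carbon bound to an amide-type nitrogen. In this assay compound 2 likewise stops at the limit of > 100000 nM. The step that the two limits leave unreadable from compound 1 to compound 2 therefore cannot be read. Compound 2 thus stands at the limit, the point where both values shown sit: the limit of > 100000 nM in this assay, at which 2 of the 2 values shown sit.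

Compound 3 `CN(Cc1ccccc1)C(=O)C1CCN(C(=O)c2cc3ccccc3n2Cc2ccc(Cl)cc2)CC1` is the next member; the change is benzyl(methyl)amino in place of ((1-methyl-1H-pyrazol-3-yl)methyl)amino on a carbonyl carbon. Among the compounds with values here, only the step from compound 1 to compound 2 bears on it, and that step is unreadable, so no readable step in this assay can be derived from the data and no direction is indicated. The expectation is that compound 3 stays at the limit, with an estimated step that the limit leaves unreadable from compound 2 to compound 3. Compound 3 is estimated at 150000 nM, range 50000 nM to 500000 nM.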

Compound 3, half-maximal cytotoxic concentration: 87000 nM
The estimate for compound 3 lay 1.7-fold (0.24 log units) above the measured number; measured number inside the range.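

In this assay, within the data shown here, compound 3 is the first member of the series to give a number rather than a limit, 87000 nM, so benzyl(methyl)amino on this carbonyl carbon brings the read-out within the measurable range. Compound 1 and compound 2 remain limits, not numbers, and this is where most of the series still sits: the limit of > 100000 nM in this assay, at which 2 of the 3 values shown sit. On these data alone, the change from the pyrazole-bearing amine gives an at least 1.1-fold lower number from compound 2 to compound 3 (0.06 log units; that floor lies within the scatter), and the change from the pyridine-bearing amine gives an at least 1.1-fold lower number from compound 1 to compound 3 (0.06 log units; that floor lies within the scatter), so neither step shows a difference beyond the scatter, and the true size of each remains unknown.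

Benzyl(methyl)amino differs from both earlier groups in its ring and in having 0 hydrogen-bond donors, so the compounds shown leave open how much the ring and the methyl each contribute; benzylamino on the same carbonyl carbon would separate the two. Also open, as far as these compounds go, is whether a carboxylic acid or a morpholine at the end of a longer chain at this position would give a number in this assay.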